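The source may report more compounds than this note shows. Statements on the series, on what has been measured and on what is new or still open speak of the compounds shown alone.

Compound 1 `COc1cc(C2=NN(C(C)=O)C(c3cc(Cl)cc(Cl)c3)O2)cc(OC)c1OC` and compound 2 `COc1ccc(OC)c(C2OC(c3cc(OC)c(OC)c(OC)c3)=NN2C(C)=O)c1` share one core and differ only in the aryl group attached to a saturated ring carbon. In a functional assay on PC-3 cells (Homo sapiens) for antiproliferative activity, read by MTT assay, tested at 5 uM (on this read-out lower numbers stand for a weaker effect and higher numbers for a stronger effect at the one concentration tested), compound 1 gives 93.9%, and compound 2 gives 43.2%. Among these two numbers compound 2 stands lowest; its only neighbour is compound 1, and the gap between them is large, as the step of a number 50.7 percentage points lower from compound 1 to compound 2 (beyond the scatter) shows.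

Compound 3 `COc1cc(C2=NN(C(C)=O)C(c3ccccc3C(F)(F)F)O2)cc(OC)c1OC` has not yet been measured in this assay. It differs from compound 2 in one place: 2-(trifluoromethyl)phenyl in place of 2,5-dimethoxyphenyl on a saturated ring carbon. Within the data shown here, the single measured step that bears on this change is a number 50.7 percentage points lower from compound 1 to compound 2 (beyond the scatter), which shows that exchanging the aryl group on this saturated ring carbon can move the read-out far beyond the usual scatter. The higher number in that pair belonged to the 3,5-dichlorophenyl compound, a group that, like the entering 2-(trifluoromethyl)phenyl, carries halogens and no hydrogen-bond acceptors.

In this assay compound 3 is therefore expected to give about 70%, within a range of 40% to 95%. The step of a number 26.8 percentage points higher from compound 2 to compound 3 (beyond the scatter) is expected to be an upward one, though its exact size is uncertain.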

Compound 3, a percentage reported as inhibition, at one concentration (the size of the read-out at that concentration, not a potency): 15.2%
Beside the measured number, compound 3's estimate is 54.8 percentage points above it; the whole stated range lies above it.
By their numbers in this assay, from the lowest: compound 3; then compound 2; then compound 1.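

In this assay, the aryl group on this saturated ring carbon now gives three clearly separated levels, with compound 3 the weakest of the three. Putting 2-(trifluoromethyl)phenyl in place of 2,5-dimethoxyphenyl lowers the read-out (a number 28 percentage points lower from compound 2 to compound 3 (beyond the scatter)), and putting it in place of 3,5-dichlorophenyl lowers it much further (a number 78.7 percentage points lower from compound 1 to compound 3 (beyond the scatter)). The two halogen-bearing groups therefore sit at opposite ends of this short series, with the methoxy-bearing compound 2 between them, so among these three compounds carrying halogens does not go with a strong effect, and compound 3 goes directly against that idea. Nothing shown here explains why these aryl groups differ so widely.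

The step from compound 1 to compound 3 changes both the kind of halogen-bearing substituent and where it sits on the aryl ring, so these compounds cannot show which of the two matters. Groups such as 2-chlorophenyl, 3,5-bis(trifluoromethyl)phenyl or 3-(trifluoromethyl)phenyl on the same ring carbon would separate those two changes, and each figure here describes a single tested concentration rather than a potency.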